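Unsubstituted amide compound 3 after the acetylazetidine amide

The source may report more compounds than this note shows. Statements on the series, on what has been measured and on what is new or still open speak of the compounds shown alone.

Values in an ADME assay (liver) for pharmacokinetics, with Liver microsome (Rattus norvegicus) as the target, read by LC-MS, using microsomes, with a stated time of 1 h; on this read-out lower numbers stand for slow clearance and higher numbers for fast clearance:
- compound 1 `N#CCNC(=O)c1cnc(N)c2cc(-c3cccc(F)c3)ccc12`: 23 mL/min/kg
- compound 2 `CC(=O)N1CC(NC(=O)c2cnc(N)c3cc(-c4cccc(F)c4)ccc23)C1`: 9 mL/min/kg
- compound 3 `NC(=O)c1cnc(N)c2cc(-c3cccc(F)c3)ccc12`: not yet measured

Compound 2 holds the lower of the two numbers, and compound 1 stands above it. The next change is hydrogen in place of 1-acetylazetidin-3-yl on an amide-type nitrogen. Within the data shown here, one measured step bears on this, at the same nitrogen: a 2.6-fold lower number from compound 1 to compound 2 (0.41 log units; beyond the scatter), modest and beyond the scatter. Among the measured compounds shown here, no measured compound carries hydrogen there, so the direction rests on this single comparison. A move toward higher numbers in this assay is expected, no larger than that measured step. The expected step is a 1.8-fold higher number from compound 2 to compound 3 (0.25 log units; within the scatter). For compound 3 the estimate is 16 mL/min/kg, with an expected range of 7 mL/min/kg to 35 mL/min/kg.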

Compound 3, clearance: 40 mL/min/kg
For compound 3 the middle estimate is 2.5-fold (0.40 log units) below the measured one; the whole stated range lies below it.
By their numbers in this assay, from the lowest: compound 2; then compounds 1 and 3 (each within the scatter of the next).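

In this assay, the step to the unsubstituted amide is a 4.4-fold higher number from compound 2 to compound 3 (0.65 log units; beyond the scatter) and so undoes the gain seen in a 2.6-fold lower number from compound 1 to compound 2 (0.41 log units; beyond the scatter) at the same amide-type nitrogen. Against hydrogen, cyanomethyl gives only a 1.7-fold higher number from compound 1 to compound 3 (0.24 log units; within the scatter) and stays within the scatter, so among these three compounds only the 1-acetylazetidin-3-yl group sets its compound apart, and a substituent on this nitrogen does not by itself bring the lower number. Nothing measured here gives a reason for this difference.

The compounds shown leave open whether the lower number goes with the four-membered ring, with the acetyl group or with the two together. An azetidin-3-yl group carrying a free amine, or an open chain ending in an acetamide, on the same nitrogen would separate these readings.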